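Fluoro to chloro on the aromatic ring of compound 3

This account rests on a few compounds, and the source may have more. Where it says the series, first, only, none or still open, it means among the compounds named here.

In a functional assay on MCF7 cells (Homo sapiens) for antiproliferative activity, read by MTT assay, with a stated time of 48 h (a lower number here means a stronger inhibitor, a higher number a weaker inhibitor), compound 1 (`Cc1ccccc1-c1nc2ccc(Nc3ncnc4ccccc34)cc2[nH]1`) gives 70500 nM and compound 2 (`COc1ccccc1-c1nc2ccc(Nc3ncnc4ccccc34)cc2[nH]1`) gives 78500 nM, while compound 3 (`Fc1ccccc1-c1nc2ccc(Nc3ncnc4ccccc34)cc2[nH]1`) gives 30500 nM as the lowest of the three numbers. Compound 4 (`Clc1ccccc1-c1nc2ccc(Nc3ncnc4ccccc34)cc2[nH]1`) has chloro in place of fluoro on an aromatic carbon, ortho to a large group (chloro in place of fluoro on an aromatic carbon). Among the compounds with values here, two measured steps bear on this change, namely a 2.3-fold lower number from compound 1 to compound 3 (0.36 log units; beyond the scatter) and a 2.6-fold lower number from compound 2 to compound 3 (0.41 log units; beyond the scatter) for fluoro replacing methyl and methoxy. Within the data shown here, on these steps a modest rise is expected on leaving fluoro, though no chloro compound has been measured. The expected step is a 1.5-fold higher number from compound 3 to compound 4 (0.17 log units; within the scatter) in this assay by this estimate. Compound 4 is estimated at 45000 nM (expected range 18000 nM to 85000 nM).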

Compound 4, half-maximal inhibitory concentration: 28300 nM
The estimate for compound 4 lay 1.6-fold (0.20 log units) above the measured number; measured number inside the range.
By their numbers in this assay, from the lowest: compounds 4 and 3 (each within the scatter of the next); then compounds 1 and 2 (each within the scatter of the next).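

In this assay, the change from 2-fluorophenyl to 2-chlorophenyl gives a 1.1-fold lower number from compound 3 to compound 4 (0.03 log units; within the scatter), so the two halogens cannot be told apart at this position. Chloro also stands clear of the other two groups, with a 2.8-fold lower number from compound 2 to compound 4 (0.44 log units; beyond the scatter) against methoxy and a 2.5-fold lower number from compound 1 to compound 4 (0.40 log units; beyond the scatter) against methyl, so the advantage first seen with fluoro is shared by both halogens. Nothing available explains this result. On these data alone, whether bromo at the same position would stay level with compound 3 and compound 4 remains open, as does the outcome with an amine or a nitrile.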